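The source may hold more compounds than are shown below. What is called first, only, known or untested is meant among the compounds shown, and "the series" means these compounds.

Measured compounds:
- compound 1 `CC(C)NC(=O)NS(=O)(=O)c1cc(C#N)ccc1Oc1ccc(Cl)cc1`: 9460 nM in a functional assay on HEK293 cells for antagonist activity at thromboxane A2 receptor (Homo sapiens), read by fluorescence and calcium flux; a lower number here means a stronger inhibitor, a higher number a weaker inhibitor
- compound 2 `CC(C)(C)NC(=O)NS(=O)(=O)c1cc(C#N)ccc1Oc1ccc(Cl)cc1`: 5640 nM in this assay
- compound 3 `CC(C)NC(=O)NS(=O)(=O)c1cc(C#N)ccc1Oc1ccc(Br)cc1`: 9470 nM in this assay

Compound 4 `CC(C)(C)NC(=O)NS(=O)(=O)c1cc(C#N)ccc1Oc1ccc(Br)cc1` is not yet measured. The change from compound 3 to compound 4 is methyl in place of hydrogen on a saturated chain carbon bound to an amide-type nitrogen and two saturated chain carbons. The same change appears once among the measured pairs, as methyl in place of hydrogen on a saturated chain carbon bound to an amide-type nitrogen and two saturated chain carbons, where the step was a 1.7-fold lower number from compound 1 to compound 2 (0.22 log units; within the scatter). The two cores differ by bromo in place of chloro on an aromatic carbon, and that exchange gave a 1.0-fold higher number from compound 1 to compound 3 (0.00 log units; within the scatter), so the two parents sit essentially together. The place of the change is described in the same words in both pairs. Among the compounds with values here, on the single precedent from compound 1 to compound 2, the step from compound 3 to compound 4 is expected to be a 1.7-fold lower number from compound 3 to compound 4 (0.22 log units; within the scatter). Compound 4 is therefore estimated at 5700 nM, with a range from 3000 nM to 11000 nM expected.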

Compound 4, half-maximal inhibitory concentration: 5880 nM
Compound 4: the middle estimate sits 1.0-fold (0.01 log units) below what was measured; the range from low to high includes it.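

Isopropyl to tert-butyl gives a 1.6-fold lower number from compound 3 to compound 4 (0.21 log units; within the scatter), and this small step carries from the core of compound 1 to the core of compound 3: the same change on two cores in this assay, a 1.7-fold lower number (0.22 log units; within the scatter) from compound 1 to compound 2 and a 1.6-fold lower number (0.21 log units; within the scatter) from compound 3 to compound 4, 1.0-fold (0.02 log units) apart, within the scatter of two such steps. Bromo in place of chloro gives a 1.0-fold higher number from compound 2 to compound 4 (0.02 log units; within the scatter), and it likewise reads the same on both cores: the same change on two cores in this assay, a 1.0-fold higher number (0.00 log units; within the scatter) from compound 1 to compound 3 and a 1.0-fold higher number (0.02 log units; within the scatter) from compound 2 to compound 4, 1.0-fold (0.02 log units) apart, within the scatter of two such steps. Within the data shown here, each step lies within the scatter, so the data show two exchanges that stay small on both cores, but they establish no real gain from tert-butyl and no order between the halogens, and each comparison rests on only two pairs.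

Still open, from the compounds shown here alone, is how a cyclohexyl group or a longer chain in place of tert-butyl, or a methoxy group in place of bromo, would read in this assay. Also open, going by these compounds, is whether a carboxylic acid in place of the nitrile would move the number beyond the scatter.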